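The source may hold more compounds than are shown below. What is called first, only, known or untested is meant among the compounds shown, and "the series" means these compounds.

Compound 1 `COc1cccc(OC)c1C(=O)Nc1c[nH]nc1C(=O)N[C@H]1CC[C@H](OC)CC1` is examined in an ADME assay on MRC5 cells (Homo sapiens) for inhibition, with a stated time of 72 h (on this read-out higher numbers stand for an effect only at larger amounts of compound and lower numbers for an effect already at smaller amounts), where compound 1 gives 31000 nM. Among the compounds with values here, of the two numbers known, compound 1 stands highest; compound 3 `CO[C@H]1CC[C@H](NC(=O)c2n[nH]cc2NC(=O)c2cc3ccccn3n2)CC1` gives 1000 nM, a gap beyond the usual scatter. Compound 2 `COc1cccc(OC)c1C(=O)Nc1c[nH]nc1C(=O)NC1CCN(C(=O)OC(C)(C)C)CC1` reports > 50000 nM in this assay, which is a limit of the assay and not a number. Compound 4 `COc1cccc(OC)c1C(=O)Nc1c[nH]nc1C(=O)NC1CCCCC1` differs from compound 1 by hydrogen in place of methoxy on a saturated ring carbon. Within the data shown here, no measured pair shows this change in this assay, so its effect can only be estimated: the step is expected to be small, a 1.0-fold higher number from compound 1 to compound 4 (0.01 log units; within the scatter), with no direction beyond the scatter. Compound 4 is therefore expected to give about 32000 nM in this assay, between 13000 nM and 50000 nM.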

Compound 4, half-maximal effective concentration: 35000 nM
The estimate for compound 4 lay 1.1-fold (0.04 log units) below the measured number; the measured number falls inside the stated range.
By their numbers in this assay, from the lowest: compound 3; then compounds 1 and 4 (each within the scatter of the next). At a limit, above all of these: compound 2.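

In this assay, removing the methoxy leaves the read-out essentially unchanged: the change gives a 1.1-fold higher number from compound 1 to compound 4 (0.05 log units; within the scatter), so 4-methoxycyclohexyl and cyclohexyl cannot be told apart here. This is the only step shown at this position, and the earlier compounds offered no comparison that differs in one place. The read-out also has an upper end, and compound 2 stands at a limit of it: the limit of > 50000 nM in this assay, at which 1 of the 4 values shown sits.

As far as these compounds go, whether an amine or a carboxylic acid on this ring carbon would move the number beyond the scatter stays open. So does whether the same change would leave compound 3 equally unmoved.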